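Amine swap on the shared triazole carbon: compound 2 to 4

The source may report more compounds than this note shows. Statements on the series, on what has been measured and on what is new or still open speak of the compounds shown alone.

In a functional assay on A-431 cells (Homo sapiens), tested at 0.1 uM (on this read-out higher numbers stand for more inhibition at the one concentration tested (going by the name of the read-out) and lower numbers for less inhibition), compound 1 `COc1cccc(Nc2n[nH]c(-c3cccnc3Nc3cc(OC)cc(OC)c3)n2)c1` gives 72% and compound 3 `COc1cccc(CNc2n[nH]c(-c3cccnc3Nc3cc(OC)cc(OC)c3)n2)c1` gives 71%. For compound 2 `COc1cc(Nc2ncccc2-c2n[nH]c(Nc3cc(Cl)cc(Cl)c3)n2)cc(OC)c1` the result in this assay is "not determined" (no result reported), so compound 2 stands without a number. Compound 4 `COc1cc(Nc2ncccc2-c2n[nH]c(N(C)C3CCCO3)n2)cc(OC)c1` differs from compound 2 by methyl(oxolan-2-yl)amino in place of (3,5-dichlorophenyl)amino on an aromatic carbon. Within the data shown here, the only measured step at that same aromatic carbon is a number 1 percentage points lower from compound 1 to compound 3 (within the scatter), a change that kept an aromatic ring on the nitrogen. Among the measured compounds shown here, compound 4 instead loses the aromatic ring and the donor there, a larger change for which no measured step exists. Compound 4 is therefore expected to give an inhibition of about 45% in this assay, with a wide range from 15% to 75%.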

Compound 4, a percentage reported as inhibition, at one concentration (the size of the read-out at that concentration, not a potency): 36%
Compound 4: middle estimate off by 9 percentage points, on the high side; low and high end bracket the measured number.
By their numbers in this assay, from the lowest: compound 4; then compounds 3 and 1 (each within the scatter of the next).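

Compound 2 has no number in this assay, so the step from compound 2 to compound 4 cannot be read. Going by these compounds, whether methyl(oxolan-2-yl)amino gives less inhibition than (3,5-dichlorophenyl)amino on the same core stays open. Nothing measured here offers an explanation for the result of compound 4.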